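Smaller Cap on the Ring Nitrogen: Compound 2 to Compound 3

This account rests on a few compounds, and the source may have more. Where it says the series, first, only, none or still open, it means among the compounds named here.

Measured so far in a functional assay on U2OS cells for antagonist activity at proto-oncogene Wnt-3 (Homo sapiens), read by a luciferase reporter, with a stated time of 18 h; on this read-out lower numbers stand for an effect already at smaller amounts and higher numbers for an effect only at larger amounts of compound:
Compound 1 `CC(C)(C)C(=O)N1CCC[C@H]1C(=O)N1CCC(NS(=O)(=O)c2cc(S(=O)(=O)c3ccccc3)ccc2C(F)(F)F)CC1` gives 270 nM
Compound 2 `O=C([C@@H]1CCCN1C(=O)N1CCOCC1)N1CCC(NS(=O)(=O)c2cc(S(=O)(=O)c3ccccc3)ccc2C(F)(F)F)CC1` gives 280 nM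

Compound 2 holds the higher of the two numbers, yet a 1.0-fold higher number from compound 1 to compound 2 (0.02 log units; within the scatter), so the pair cannot be told apart. Compound 3 `CN1CCC[C@H]1C(=O)N1CCC(NS(=O)(=O)c2cc(S(=O)(=O)c3ccccc3)ccc2C(F)(F)F)CC1` differs from compound 2 by methyl in place of (morpholin-4-yl)carbonyl on an amine nitrogen in a ring. Among the measured compounds shown here, the one measured step only swapped one carbonyl-bearing group for another; nothing measured removes the carbonyl itself, so guidance is weak. A modest loss is expected, a 2.1-fold higher number from compound 2 to compound 3 (0.33 log units; beyond the scatter). Compound 3 is estimated at 600 nM, with a range from 150 nM to 3000 nM.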

Compound 3, half-maximal effective concentration: 230 nM
The estimate for compound 3 lay 2.6-fold (0.42 log units) above the measured number; the measured number falls inside the stated range.
By their numbers in this assay, from the lowest: compounds 3, 1 and 2 (each within the scatter of the next).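

In this assay, replacing the whole carbonyl-bearing cap on the ring nitrogen with methyl gives (a 1.2-fold lower number from compound 2 to compound 3 (0.09 log units; within the scatter)) and (a 1.2-fold lower number from compound 1 to compound 3 (0.07 log units; within the scatter)), so all three compounds cannot be told apart. Across these compounds, this nitrogen therefore carries a small methyl as well as either larger cap, and the carbonyl and the morpholine ring are not needed to keep the number in this range. No outside evidence bears on why this is so.

The compounds shown leave open whether a plain hydrogen on this nitrogen, or a longer chain ending in a carboxylic acid, would fit equally well.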